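The source may report more compounds than this note shows. Statements on the series, on what has been measured and on what is new or still open speak of the compounds shown alone.

Of the compounds shown here, three built on one shared core have been tested in a functional assay on A549 cells (Homo sapiens) for antiproliferative activity, read by MTT assay; a lower number here means a stronger inhibitor, a higher number a weaker inhibitor. Compound 2 `Clc1ccc(Nc2nccc(-c3ccc(Br)cc3)n2)c(Cl)c1` gives 3780 nM. Compound 1 `COc1ccc(-c2ccnc(Nc3ccc(Cl)cc3Cl)n2)cc1` carries methoxy in place of bromo on an aromatic carbon and gives 7330 nM, so that a 1.9-fold higher number from compound 2 to compound 1 (0.29 log units; within the scatter). Compound 3 `Clc1ccc(Nc2nccc(-c3ccc(Br)cc3)n2)cc1` differs from compound 2 by hydrogen in place of chloro on an aromatic carbon; in this assay compound 3 gives 6110 nM, and a 1.6-fold higher number from compound 2 to compound 3 (0.21 log units; within the scatter). All three numbers sit within the usual scatter of one another, so no order among them can be read from these data.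

Compound 4 `COc1ccc(-c2ccnc(Nc3ccc(Cl)cc3)n2)cc1` has not yet been measured. Among the measured compounds shown here, it differs from compound 3 by methoxy in place of bromo on an aromatic carbon, which is the same change, at the same place on the ring, as the one that leads from compound 2 to compound 1, where the effect stayed within the scatter. Because the earlier step of a 1.9-fold higher number from compound 2 to compound 1 (0.29 log units; within the scatter) was small, the step for compound 4 is expected to be of similar size, a 1.8-fold higher number from compound 3 to compound 4 (0.26 log units; within the scatter). Compound 4 is therefore estimated at 11000 nM in this assay, with a likely range from 5000 nM to 25000 nM.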

Compound 4, half-maximal inhibitory concentration: 20900 nM
The estimate for compound 4 lay 1.9-fold (0.28 log units) below the measured number; the range from low to high includes it.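

Methoxy in place of bromo gives a 3.4-fold higher number from compound 3 to compound 4 (0.53 log units; beyond the scatter) in this assay, and this step agrees with the earlier one on the other core: the same change on two cores in this assay, a 1.9-fold higher number (0.29 log units; within the scatter) from compound 2 to compound 1 and a 3.4-fold higher number (0.53 log units; beyond the scatter) from compound 3 to compound 4, 1.8-fold (0.25 log units) apart, within the scatter of two such steps Hydrogen in place of chloro gives a 2.9-fold higher number from compound 1 to compound 4 (0.46 log units; beyond the scatter), and this step also agrees with its earlier counterpart: the same change on two cores in this assay, a 1.6-fold higher number (0.21 log units; within the scatter) from compound 2 to compound 3 and a 2.9-fold higher number (0.46 log units; beyond the scatter) from compound 1 to compound 4, 1.8-fold (0.25 log units) apart, within the scatter of two such steps Each change therefore carried over between these two cores in the same direction and with no difference that can be told from the scatter, but the earlier step in each pair lies within the scatter, so this does not show that the paired steps are equal in size, nor that either change would behave alike on any further core.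

The compounds shown leave open what an amine, a carboxylic acid or a longer chain would give in place of bromo or methoxy in this assay. They also leave open whether these steps would look the same on cells of another kind.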